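This account rests on a few compounds, and the source may have more. Where it says the series, first, only, none or still open, it means among the compounds named here.

Working notes on the series. Among the compounds with values here, in a functional assay on HeLa cells (Homo sapiens) for inhibition, read by MTT assay, with a stated time of 24 h, tested at 5 uM (a higher number here means more inhibition of growth at the concentration tested, a lower number less inhibition of growth), compound 2 `CS(=O)(=O)c1ccc(-c2cnc3[nH]cc(-c4nnc(-c5ccccc5)o4)c(=O)c3c2)cc1` gives 8.58%, the highest of the two numbers so far; compound 1 `CS(=O)(=O)c1ccc(-c2cnc3[nH]cc(-c4nnc(-c5ccncc5)o4)c(=O)c3c2)cc1` gives 7.08% in this assay, and the step of a number 1.5 percentage points higher from compound 1 to compound 2 (within the scatter) lies within the scatter, so the two compounds cannot be told apart on this read-out. Compound 3 `CS(=O)(=O)c1ccc(-c2cnc3[nH]cc(-c4nnc(-c5ccc(Cl)cc5)o4)c(=O)c3c2)cc1` carries the change (chloro in place of hydrogen on an aromatic carbon), the place being para to a large group. Within the data shown here, no measured step bears directly on this change; the only step available, a number 1.5 percentage points higher from compound 1 to compound 2 (within the scatter), concerns a different position and was itself within the scatter. The expectation for compound 3 therefore rests on compound 2 alone, and no movement beyond the scatter is expected: the estimated step is a number 0.4 percentage points higher from compound 2 to compound 3 (within the scatter). Compound 3 is expected to give about 9% in this assay, with a range from 0% to 22%.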

Compound 3, percent growth inhibition at one concentration: 1.07%
For compound 3 the middle estimate is 7.9 percentage points above the measured one; low and high end bracket the measured number.
By their numbers in this assay, from the lowest: compounds 3, 1 and 2 (each within the scatter of the next).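

In this assay, within the data shown here, chloro in place of hydrogen on an aromatic carbon, para to a large group, gives a number 7.5 percentage points lower from compound 2 to compound 3 (within the scatter) and so provides the first reading of a substituent at this place, one that does not separate the two compounds. The change of pyridin-4-yl to 4-chlorophenyl reads the same way, with a number 6 percentage points lower from compound 1 to compound 3 (within the scatter) as its step. Phenyl, pyridin-4-yl and 4-chlorophenyl therefore cannot be told apart on this read-out, and the three compounds give no ranking among these groups.

On these data alone, whether an amine, a carboxylic acid or a longer chain at this place would give a step beyond the scatter remains open. No independent measurement is available to account for these readings.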